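A Smaller Ring on the Aromatic Carbon

This account rests on a few compounds, and the source may have more. Where it says the series, first, only, none or still open, it means among the compounds named here.

Compound 1, `C/C(=N\OCC(=O)O)c1ccc(C(C)(C)C)cc1`: < 20%
Compound 2, `C/C(=N\OCC(=O)O)c1ccc(CC2CCCCC2)cc1`: < 20%

In a functional assay on the whole organism for inhibition, with Rattus norvegicus as the target, read by paw edema, with stated times of 1 h and 3 h, at a dose of 50 mg/kg by the oral route (on this read-out lower numbers stand for less inhibition and higher numbers for more inhibition at the one dose given (going by the name of the read-out)), compound 1 gives < 20%, which is a limit of the assay rather than a number. Compound 2 gives < 20% in this assay, again a limit. Going by the values given here, the one step among the measured compounds, a step that the two limits leave unreadable from compound 1 to compound 2, cannot be read because both ends are limits. Compound 3 is `C/C(=N\OCC(=O)O)c1ccc(C2CC2)cc1`; it differs from compound 2 by cyclopropyl in place of cyclohexylmethyl on an aromatic carbon.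

Among the compounds with values here, no measured step bears on this change, and neither measured compound offers a number to anchor it. What is known is that both measured values sit at the limit (the limit of < 20% in this assay, at which 2 of the 2 values shown sit). The expectation for compound 3 is therefore that it stays where compound 2 stands, with no step beyond the scatter. Compound 3 is estimated at 12%, in a range from 0% to 25%, which means an expected step that the limit leaves unreadable from compound 2 to compound 3. Whether the assay will report a number at all for compound 3 is open.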

Compound 3, a percentage reported as inhibition, in the whole organism at one dose (the size of the read-out at that dose, not a potency): < 20%
Compound 3: a limit, no number (the forecaster's own chance of this, stated with the estimate: 80%); the middle value does not contradict the limit.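

No new step can be read among compound 1, compound 2 and compound 3, because all three stand at a limit and none gives a number: the limit of < 20% in this assay, at which 3 of the 3 values shown sit. The compounds shown leave open how these three groups on the aromatic carbon rank, and whether any group there would give a readable inhibition.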